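A few compounds are considered here, and "the series" means these few. Any claim that something is new, unique, unknown or untested is made for them only; others in the source may bear on it.

Within the data shown here, in an assay on isolated protein for inhibition of squalene synthase (Homo sapiens), read by scintillation counting, with a stated time of 10 min (on this read-out lower numbers stand for stronger inhibition and higher numbers for weaker inhibition), compound 3 `CC(C)C[C@H]1C(=O)N(CC(=O)NCCCCCC(=O)O)C[C@H](c2ccccc2Cl)c2cc(Cl)ccc21` stands apart from its companions as the only compound that returns a number, giving 2400 nM. Compound 1 `CC(C)C[C@H]1C(=O)N(CC(=O)O)C[C@H](c2ccccc2Cl)c2cc(F)ccc21` returns in this assay only a limit of the assay, > 20000 nM. Compound 2 `CC(C)C[C@H]1C(=O)N(CC(=O)O)C[C@H](c2ccccc2Cl)c2ccccc21` likewise returns in this assay only a limit, > 20000 nM. Among the measured compounds shown here, the single step recorded among the measured compounds, a step that the two limits leave unreadable from compound 1 to compound 2, is thus unreadable, as both of its values rest at the limit of > 20000 nM in this assay, at which 2 of the 3 values shown sit. Compound 4 `CC(C)C[C@H]1C(=O)N(CC(=O)N2CCC(C(=O)O)CC2)C[C@H](c2ccccc2Cl)c2cc(Cl)ccc21` differs from compound 3 in one place: 4-carboxypiperidin-1-yl in place of (5-carboxypentyl)amino on a carbonyl carbon. For the measured compounds named here, none of the measured compounds varies at this part of the molecule, and the one step on record is unreadable, so the measured data give no direction for the change and no ground to expect a shift beyond the usual scatter of this assay. Taking compound 3 as the anchor, the value expected for compound 4 in this assay is 3000 nM, with a range from 800 nM to 12000 nM. The step this expectation implies, a 1.3-fold higher number from compound 3 to compound 4 (0.10 log units; within the scatter), is expected to stay within the ordinary scatter of repeated measurements.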

Compound 4, half-maximal inhibitory concentration: 930 nM
Beside the measured number, compound 4's estimate is 3.2-fold (0.51 log units) above it, within the range that was stated.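

Among these compounds, the one step among the earlier compounds could not be read, so the carbonyl carbon position gives the first readable change: in this assay there is a 2.6-fold lower number from compound 3 to compound 4 (0.41 log units; beyond the scatter) when the open chain gives way to the ring. The step is modest, yet it lies beyond the scatter, which shows that the inhibition reported here responds to the form of this group and not only to its make-up. The two groups hold the same number of heavy atoms of the same elements, so the swap alters the arrangement: the chain of (5-carboxypentyl)amino closes into the six-membered non-aromatic ring of 4-carboxypiperidin-1-yl, and the amide hydrogen is lost.

The compounds shown do not separate the ring from the loss of that hydrogen, a question that a methyl group on the amide nitrogen of the open chain would address, and they do not say how a shorter chain, a longer chain or an ester in place of the carboxylic acid would read. Nothing on record gives a measured property that accounts for the step.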